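Cyanophenyl to methylpyridinyl swap on the oxazole series

The compounds below may be only part of what the source reports. "The series", "measured", "known", "first", "only" and "open" are said of these compounds alone.

Measured so far:
compound 1 `N#Cc1cccc(-c2cnc(C(=O)CCCCCCc3ccccc3)o2)c1`: 15 nM
compound 2 `N#Cc1ccc(-c2cnc(C(=O)CCCCCCc3ccccc3)o2)cc1`: 40 nM

Within the data shown here, in an assay (Rattus norvegicus) for inhibition of Fatty-acid amide hydrolase 1 (Homo sapiens) (on this read-out lower numbers stand for stronger inhibition and higher numbers for weaker inhibition), compound 2 gives 40 nM, the higher of the two numbers; the only neighbour is compound 1 at 15 nM. Among the measured compounds shown here, the single measured step, a 2.7-fold higher number from compound 1 to compound 2 (0.43 log units; beyond the scatter), moved a nitrile around one ring and gave a modest shift. Compound 3 `Cc1cccnc1-c1cnc(C(=O)CCCCCCc2ccccc2)o1` carries a different change: 3-methylpyridin-2-yl in place of 4-cyanophenyl on an aromatic carbon. For the measured compounds named here, no measured step covers an aryl-to-heteroaryl swap of this kind, so the expectation rests on compound 2 alone. Compound 3 is expected near 20 nM, within 5 nM to 80 nM. That estimate amounts to a 2.0-fold lower number from compound 2 to compound 3 (0.30 log units; within the scatter), a step expected to stay modest in either direction.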

Compound 3, inhibition constant: 15 nM
The estimate for compound 3 lay 1.3-fold (0.12 log units) above the measured number; low and high end bracket the measured number.
By their numbers in this assay, from the lowest: compounds 1 and 3 (each within the scatter of the next); then compound 2.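

In this assay the change to 3-methylpyridin-2-yl gives a 2.7-fold lower number from compound 2 to compound 3 (0.43 log units; beyond the scatter) and no change at the digits printed from compound 1 to compound 3 (within the scatter) on the aromatic carbon next to the ring oxygen. At this position, a nitrile is therefore not needed to match compound 1, and a six-membered aromatic ring with 1 hetero atom is accepted. Nothing available gives a reason for either step. From the compounds shown here alone, the methyl group and the ring nitrogen enter together, so which of them carries the result stays open. Also open, going by these compounds, is how an amine or a carboxylic acid on this ring would read.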